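The source may hold more compounds than are shown below. What is called first, only, known or untested is meant among the compounds shown, and "the series" means these compounds.

Measured in an ADME assay on HEK293 cells (Homo sapiens) for antiproliferative activity, read by MTT assay, with a stated time of 24 h; on this read-out lower numbers stand for stronger inhibition and higher numbers for weaker inhibition:
- compound 1, `COc1ccc(-c2cc(/C=C/C(=O)c3cc(OC)c(OC)c(OC)c3)nc3cc(-c4ccccc4)nn23)cc1OC`: 35000 nM
- compound 2, `COc1cc(/C=C/C(=O)c2cc(-c3cc(OC)c(OC)c(OC)c3)n3nc(-c4ccccc4)cc3n2)cc(OC)c1OC`: 41000 nM
- compound 3, `COc1cc(-c2cc(/C=C/C(=O)c3ccc(C)c(C)c3)nc3cc(-c4ccccc4)nn23)cc(OC)c1OC`: 72500 nM

Among these three, compound 1 carries the lowest number. Compound 2 lies within the scatter of it, so the two cannot be told apart on this read-out. Compound 3 sits beyond the scatter, with a number about double that of compound 1, and it is the only one of the three without a trimethoxyphenyl on the carbonyl carbon.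

Compound 4, `COc1ccc(C(=O)/C=C/c2cc(-c3ccc(OC)c(OC)c3)n3nc(-c4ccccc4)cc3n2)cc1`, has not yet been measured in this assay. It differs from compound 1 in one place: 4-methoxyphenyl in place of 3,4,5-trimethoxyphenyl on a carbonyl carbon. Among the compounds with values here, no measured pair in this set shows exactly this exchange, so its effect must be inferred. Within the data shown here, the one comparison available, compound 3 against compound 1, points the same way, with a plainer aryl group on the carbonyl carbon giving the higher number.

On that basis compound 4 is expected to give a higher number than compound 1, with a step of a 1.6-fold higher number from compound 1 to compound 4 (0.20 log units; within the scatter) that is modest but likely beyond the scatter. The estimate for compound 4 in this assay is 55000 nM, with a range from 25000 nM to 120000 nM.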

Compound 4, half-maximal inhibitory concentration: 40000 nM
Beside the measured number, compound 4's estimate is 1.4-fold (0.14 log units) above it, within the range that was stated.
By their numbers in this assay, from the lowest: compounds 1, 4, 2 and 3 (each within the scatter of the next, the first and the last beyond it).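

In this assay, putting 4-methoxyphenyl in place of 3,4,5-trimethoxyphenyl on a carbonyl carbon gives a 1.1-fold higher number from compound 1 to compound 4 (0.06 log units; within the scatter), so compound 1 and compound 4 cannot be told apart on this read-out. Within the data shown here, this is the first direct one-place comparison at this position, and it shows that, with the rest of compound 1 kept, the full 3,4,5-trimethoxyphenyl is not required to hold the number at this level. Nothing at hand explains why the exchange leaves the reading within the scatter.

As far as these compounds go, it remains open whether any methoxy group is needed here, which a plain phenyl on the carbonyl carbon would test. A pyridine ring or a carboxylic acid on that aryl ring could likewise show whether this position tolerates more than methoxy-substituted phenyl groups.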